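Amide substituent exchange from compound 2 to compound 3

A few compounds are considered here, and "the series" means these few. Any claim that something is new, unique, unknown or untested is made for them only; others in the source may bear on it.

Compound 1 `Cc1cc(C(=O)O)nn1Cc1cc(Br)ccc1OCc1ccccc1` carries a free carboxylic acid, and in an assay on CHO-K1 cells for displacement of a labelled ligand from prostaglandin E2 receptor EP1 subtype (Homo sapiens) (on this read-out higher numbers stand for weaker inhibition and lower numbers for stronger inhibition), compound 1 gives 6.31 nM. Compound 2 `Cc1cc(C(=O)Nc2cccc(F)c2)nn1Cc1cc(Cl)ccc1OCc1ccccc1` is an amide on a closely related core; in this assay compound 2 gives 200 nM, the highest of the two numbers recorded so far and well beyond the scatter from compound 1. Compound 3 `Cc1cc(C(=O)NCc2ccccn2)nn1Cc1cc(Cl)ccc1OCc1ccccc1` has not been measured. It differs from compound 2 in one place: (pyridin-2-yl)methyl in place of 3-fluorophenyl on an amide-type nitrogen. For the measured compounds named here, no measured pair shows this kind of change, so nothing here fixes its direction or size. For compound 3 a step of a 1.5-fold higher number from compound 2 to compound 3 (0.18 log units; within the scatter) is expected, kept small and with a wide range because only compound 2 with 200 nM anchors the amide side of the series. Compound 3 is therefore estimated at 300 nM, with a range from 60 nM to 1500 nM.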

Compound 3, half-maximal inhibitory concentration: 25.1 nM
Compound 3: the middle estimate sits 12-fold (1.08 log units) above what was measured; the measured number lies below the stated range.
By their numbers in this assay, from the lowest: compound 1; then compound 3; then compound 2.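

The substituent on the amide-type nitrogen clearly affects the read-out in this assay: (pyridin-2-yl)methyl in place of 3-fluorophenyl gives an 8.0-fold lower number from compound 2 to compound 3 (0.90 log units; beyond the scatter). The two groups have the same heavy-atom count, but the exchange changes several features at once: fluorine is lost, a ring nitrogen and a hydrogen-bond acceptor are gained, and a methyl link now separates the ring from the amide-type nitrogen. No measurement here explains the step.

A benzyl group or a directly attached pyridin-2-yl group on the same nitrogen would help separate the contribution of the ring nitrogen from that of the methyl link. The chlorine analogue of the carboxylic acid in compound 1 would allow a one-place comparison between the acid and the amides, which the compounds shown do not provide.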